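The source may hold more compounds than are shown below. What is called first, only, known or untested is meant among the compounds shown, and "the series" means these compounds.

In a functional assay on K562 cells (Homo sapiens) for cytotoxicity (on this read-out lower numbers stand for stronger inhibition of growth and higher numbers for weaker inhibition of growth), compound 1 `OCCCCC#Cc1ccccc1C#Cc1ccccc1` gives 21100 nM, which places it second highest of the three numbers recorded. Compound 2 `OCCCCC#Cc1ccccc1C#Cc1ccccn1` gives 29000 nM in this assay, and compound 3 `CSc1ccccc1C#Cc1ccccc1C#CCCCCO` gives 6100 nM. The step from compound 1 to compound 2 is a 1.4-fold higher number from compound 1 to compound 2 (0.14 log units; within the scatter), whereas the step from compound 1 to compound 3 is a 3.5-fold lower number from compound 1 to compound 3 (0.54 log units; beyond the scatter).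

Compound 4 `OCCCCC#Cc1ccccc1C#Cc1cccc(C(F)(F)F)c1` differs from compound 1 by trifluoromethyl in place of hydrogen on an aromatic carbon, with the new group sitting meta to a large group. Going by the values given here, no measured step reproduces this change. The nearest precedents are the addition of a substituent to an aromatic carbon, which in compound 3 gave a modest lowering, and the alteration of the terminal ring, which in compound 2 stayed within the scatter. On that basis a step that is at most modest and more likely downward than upward is expected, a 1.8-fold lower number from compound 1 to compound 4 (0.25 log units; within the scatter). The estimate for compound 4 in this assay is therefore 12000 nM, expected to fall between 5000 nM and 30000 nM.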

Compound 4, concentration for 50% growth inhibition: 22500 nM
Compound 4: the middle estimate sits 1.9-fold (0.27 log units) below what was measured; the range from low to high includes it.
By their numbers in this assay, from the lowest: compound 3; then compounds 1, 4 and 2 (each within the scatter of the next).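

In this assay, trifluoromethyl in place of hydrogen on an aromatic carbon, meta to a large group, leaves the read-out within the scatter (a 1.1-fold higher number from compound 1 to compound 4 (0.03 log units; within the scatter)). The earlier compounds shown here offered only one substituent added to an aromatic carbon, and that step lay beyond the scatter (a 3.5-fold lower number from compound 1 to compound 3 (0.54 log units; beyond the scatter)), so compound 4 shows that adding a group to an aromatic carbon of the core does not in every case lower the number. Nothing available explains why this substitution leaves the read-out within the scatter.

The compounds shown leave open how methylsulfanyl would behave at the place trifluoromethyl occupies in compound 4, so the effect of the group cannot yet be separated from that of its place. They also leave open whether an amine or a methoxy group there would give a step beyond the scatter.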